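Alkyl Ketone Variation on a Cytotoxic Aminothiophene Core

A few compounds are considered here, and "the series" means these few. Any claim that something is new, unique, unknown or untested is made for them only; others in the source may bear on it.

Compound 2 `CCC(=O)c1sc2nc(-c3cccs3)ccc2c1N` is a ketone carrying an ethyl group on its carbonyl carbon. Going by the values given here, in a functional assay on WI-38 VA13 cells (Homo sapiens) for cytotoxicity (on this read-out higher numbers stand for an effect only at larger amounts of compound and lower numbers for an effect already at smaller amounts), compound 2 gives 0.89 ug/mL, the highest of the two numbers measured; the only neighbour, compound 1 `COc1ccccc1C(=O)c1sc2nc(-c3cccs3)ccc2c1N`, gives 0.059 ug/mL in this assay. Among the compounds with values here, the single step between them, a 15-fold higher number from compound 1 to compound 2 (1.18 log units; beyond the scatter), shows that replacing a 2-methoxyphenyl group with a small alkyl group on the carbonyl carbon weakens the effect considerably.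

Compound 3 `CC(C)(C)C(=O)c1sc2nc(-c3cccs3)ccc2c1N` differs from compound 2 by tert-butyl in place of ethyl on a carbonyl carbon. Within the data shown here, no measured pair compares two alkyl groups of different size on this carbon, so the only step that bears on the change, the large aryl-to-ethyl step, bears on it only loosely. A further modest weakening, or no change beyond the scatter, is expected, the step of a 1.5-fold higher number from compound 2 to compound 3 (0.16 log units; within the scatter). Compound 3 is therefore estimated at 1.3 ug/mL, within a range from 0.4 ug/mL to 4.5 ug/mL.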

Compound 3, half-maximal effective concentration: 0.57 ug/mL
Beside the measured number, compound 3's estimate is 2.3-fold (0.36 log units) above it; low and high end bracket the measured number.
By their numbers in this assay, from the lowest: compound 1; then compounds 3 and 2 (each within the scatter of the next).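

In this assay the exchange of ethyl for tert-butyl on the carbonyl carbon gives a 1.6-fold lower number from compound 2 to compound 3 (0.19 log units; within the scatter) so these two alkyl groups cannot be told apart here, even though tert-butyl has 4 carbons and ethyl only 2. Set against the aryl ketone, tert-butyl in place of 2-methoxyphenyl gives a 9.7-fold higher number from compound 1 to compound 3 (0.99 log units; beyond the scatter) so among these three compounds the 2-methoxyphenyl group stands apart from both alkyl groups. Nothing available explains these numbers.

From the compounds shown here alone, a plain phenyl group on the carbonyl carbon would help separate the contribution of the ring from that of its methoxy group, and that comparison remains open. Going by these compounds, whether the numbers stay level with a longer chain such as hexyl, or with a chain ending in an amine, also remains open.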